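The source may report more compounds than this note shows. Statements on the series, on what has been measured and on what is new or still open speak of the compounds shown alone.

Compound 1 `COc1ccc(C2=C(c3cc(OC)c(OC)c(OC)c3)CC3CCCN3C2=O)cc1O`: > 100000 nM (a limit, not a number)
Compound 2 `COc1ccc(C2=C(c3ccc(SC)cc3)CC3CCCN3C2=O)cc1Br`: 3000 nM

Both compounds were tested in a functional assay on M14 cells (Homo sapiens) for cytotoxicity; a higher number here means a weaker inhibitor of growth, a lower number a stronger inhibitor of growth. Among the measured compounds shown here, compound 2 gives 3000 nM, the only true number so far. Compound 1 reaches only a limit, > 100000 nM. The two compounds differ in more than one place, so no measured single change is available as a guide.

Compound 3 `COc1ccc(C2=C(c3ccc(SC)cc3)CC3CCCN3C2=O)cc1C` departs from compound 2 at a single spot: methyl in place of bromo on an aromatic carbon. This puts methyl in place of bromo on an aromatic carbon, ortho to a methoxy group. With one substituent exchanged and the rest of compound 2 kept, only a small shift in this assay is expected, perhaps towards a somewhat higher number. The expected size is an estimated 1.3-fold higher number from compound 2 to compound 3 (0.12 log units; within the scatter). Compound 3 is estimated at 4000 nM, with an expected range of 1200 nM to 15000 nM.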

Compound 3, concentration for 50% growth inhibition: 200 nM
The estimate for compound 3 lay 20-fold (1.30 log units) above the measured number; the whole stated range lies above it.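

In this assay, this position, ortho to a methoxy group, proves highly sensitive: exchanging bromo for methyl, each a single heavy atom, gives a 15-fold lower number from compound 2 to compound 3 (1.18 log units; beyond the scatter). Among the compounds shown here, this is the first single change that can be read, and it shows that a swap that looks minor on paper can matter a great deal here, with methyl the better of the two groups seen at this spot. Nothing in the data shown accounts for the size of this step.

From the compounds shown here alone, only bromo and methyl can be compared at this position, so it remains open whether an ethyl group, a chlorine atom or an amine would give a lower or higher number. Also open, going by these compounds, is whether the same exchange would give a similar step if the rest of the molecule were different, as this is a single pair of compounds.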